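Working notes: fluoro in place of hydrogen, compound 3

The compounds below may be only part of what the source reports. "The series", "measured", "known", "first", "only" and "open" are said of these compounds alone.

In a physicochemical assay for solubility (a lower number here means a less soluble compound, a higher number a more soluble compound), compound 2 `O=C(Nc1ccccc1Cl)c1cc(Cl)ccc1O` gives 5 ug/mL as its number, and compound 1 `O=C(Nc1ccc([N+](=O)[O-])cc1Cl)c1c(O)cccc1O` gives 7.9 ug/mL on the same read-out. These two values lie within the scatter of each other, so no order can be read from them. For the measured compounds named here, no pair of measured compounds differs in one place only, which leaves no measured step to lean on.

Compound 3 `O=C(Nc1ccc(F)cc1Cl)c1cc(Cl)ccc1O` departs from compound 2 by one change (fluoro in place of hydrogen on an aromatic carbon): fluoro in place of hydrogen on an aromatic carbon, meta to a chloro group and para to a large group. Going by the values given here, with no measured precedent for this change, the expectation rests on compound 2 at 5 ug/mL alone. No step beyond the scatter is expected in this assay in either direction. The estimated step of a 1.3-fold lower number from compound 2 to compound 3 (0.10 log units; within the scatter) is expected to stay within the scatter, with only a slight drift to the less soluble side allowed for. Compound 3 is estimated at 4 ug/mL with an expected range from 1.8 ug/mL to 9 ug/mL as the working figures.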

Compound 3, solubility: 1.2 ug/mL
The estimate for compound 3 lay 3.3-fold (0.52 log units) above the measured number; the whole stated range lies above it.
By their numbers in this assay, from the lowest: compound 3; then compounds 2 and 1 (each within the scatter of the next).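

In this assay, the series now has its first measured step between compounds that differ in one place, and it is a 4.2-fold lower number from compound 2 to compound 3 (0.62 log units; beyond the scatter) for fluoro in place of hydrogen on an aromatic carbon. This place, meta to a chloro group and para to a large group, therefore responds in this read-out: an entering group of 1 heavy atom, with no ring and no net charge, is enough to carry the number beyond the scatter, and the number goes down rather than up. No measurement at hand bears on why the number moves in this way.

This is a single pair, so it cannot separate what belongs to fluoro from what belongs to the place, and a methoxy group or an amine on the same carbon, or fluoro on another carbon of that ring, would be needed to tell the two apart. For the compounds shown here, whether the same change gives a step of similar size on the core of compound 1 also remains open, as no pair tests it.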